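This account rests on a few compounds, and the source may have more. Where it says the series, first, only, none or still open, it means among the compounds named here.

Three hydrazones sharing one core have been measured in a functional assay on A549 cells (Homo sapiens) for cytotoxicity, read by XTT assay, with a stated time of 24 h; on this read-out higher numbers stand for weaker inhibition and lower numbers for stronger inhibition. Compound 1 `Cn1nnnc1SCC(=O)N/N=C/c1ccccc1F` gives 9000000 nM. Compound 2 `Cn1nnnc1SCC(=O)N/N=C/c1cccc(F)c1` gives 6320000 nM. Compound 3 `Cn1nnnc1SCC(=O)N/N=C/c1ccccc1Cl` gives 6320000 nM. Compound 2 and compound 1 have the same atoms joined differently; the difference between the two cores is not broken down here. Compound 3 arises from compound 1 through (chloro in place of fluoro on an aromatic carbon), and a 1.4-fold lower number from compound 1 to compound 3 (0.15 log units; within the scatter). Compound 2 and compound 3 stand level at the digits given, and compound 2 sits within the scatter of compound 1, so none of the three can be separated on this read-out.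

Compound 4 `Cn1nnnc1SCC(=O)N/N=C/c1cccc(Cl)c1` is not yet measured. It arises from compound 2 through (chloro in place of fluoro on an aromatic carbon). This is the same kind of change as the one seen in the measured pair, but the place differs: in the measured pair the chloro sits ortho to a large group, whereas in compound 4 it sits meta to a large group. Because a 1.4-fold lower number from compound 1 to compound 3 (0.15 log units; within the scatter), the expected step is a 1.3-fold lower number from compound 2 to compound 4 (0.10 log units; within the scatter), resting on that single measured pair. Compound 4 is estimated to give about 5000000 nM, with a likely range from 2500000 nM to 12000000 nM.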

Compound 4, half-maximal inhibitory concentration: 7500000 nM
Compound 4: the middle estimate sits 1.5-fold (0.18 log units) below what was measured; low and high end bracket the measured number.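

In this assay, chloro in place of fluoro on an aromatic carbon, meta to a large group, gives a 1.2-fold higher number from compound 2 to compound 4 (0.07 log units; within the scatter). Set beside the same change on the other core, the two steps cannot be told apart: the same change on two cores in this assay, a 1.4-fold lower number (0.15 log units; within the scatter) from compound 1 to compound 3 and a 1.2-fold higher number (0.07 log units; within the scatter) from compound 2 to compound 4, 1.7-fold (0.23 log units) apart, within the scatter of two such steps
This agrees with the change carrying from one core to the other in this series, but only in the sense that neither step can be separated from the scatter, and it rests on just two pairs. It does not show that a step large enough to read would carry over in the same way, nor does it show that fluoro and chloro are interchangeable beyond these compounds.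

The compounds shown carry only fluoro or chloro on the aromatic ring, so it remains open whether any substituent there can move this read-out beyond the scatter. An amine or a carboxylic acid on that ring, or a longer chain in place of the methyl on the shared core, would be a sharper test.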